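This account rests on a few compounds, and the source may have more. Where it says the series, first, only, none or still open, it means among the compounds named here.

Compound 1 `CC(O)(CSc1ccccc1)c1nc(-c2ccccc2)no1` is tested in a functional assay on DU-145 cells (Homo sapiens) for cytotoxicity, read by MTT assay; on this read-out higher numbers stand for weaker inhibition and lower numbers for stronger inhibition. In this assay compound 1 gives > 100000 nM, which is a limit of the assay and not a number. Compound 2 `CC(O)(CSc1ccc(Br)cc1)c1nc(-c2ccccc2)no1` carries the change (bromo in place of hydrogen on an aromatic carbon). In this assay compound 2 gives > 100000 nM, again a limit. Between the two lies a step that the two limits leave unreadable from compound 1 to compound 2, because the limit of > 100000 nM in this assay, at which 3 of the 3 values shown sit, leaves the step unreadable. Compound 3 `CC(O)(CS(=O)(=O)c1ccccc1)c1nc(-c2ccc(Cl)cc2)no1` differs from compound 1 in its core; that difference is not broken down here. In this assay compound 3 gives > 100000 nM, once more a limit. Compound 4 `CC(O)(CS(=O)(=O)c1ccc(Br)cc1)c1nc(-c2ccc(Cl)cc2)no1` carries the change (bromo in place of hydrogen on an aromatic carbon), the same change as from compound 1 to compound 2. From compound 3 to compound 4 the expected step is a step that the limit leaves unreadable from compound 3 to compound 4, resting on the unreadable step from compound 1 to compound 2. For compound 4 the expected value is 150000 nM.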

Compound 4, half-maximal inhibitory concentration: > 100000 nM
Compound 4 gave a limit, no number (the forecaster's own chance of this, stated with the estimate: 80%); the middle value is on the limit's open side.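

Compound 3 and compound 4 both sit at a limit of the assay, not a number, so no step can be read between them, because: the limit of > 100000 nM in this assay, at which 4 of the 4 values shown sit.

The compounds shown leave open whether phenyl to 4-bromophenyl changes anything in this assay.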